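Cytotoxicity of an Amide Pair in Liver Cells

This account rests on a few compounds, and the source may have more. Where it says the series, first, only, none or still open, it means among the compounds named here.

This account concerns two measured compounds and one that awaits measurement, all judged in an ADME assay on HepG2 2.2.15 cells (Homo sapiens) for cytotoxicity; on this read-out higher numbers stand for lower toxicity in this test and lower numbers for higher toxicity in this test. Compound 1, with the structure `O=C(CCCCC(=O)Nc1ncc(Cc2ccc(F)cc2)s1)Nc1ncc(Cc2ccc(F)cc2)s1`, is a symmetric diamide. In this assay compound 1 reaches only a limit of the test, > 50000 nM, so it gives no number of its own. Compound 2, with the structure `O=C(Nc1ncc(C(Oc2ccc3cc(Br)ccc3c2)c2ccc(Cl)cc2)s1)C1CC1`, is the parent of the pair that matters here. In this assay compound 2 is reported as "not toxic" (no number reported), again with no figure attached, which is all that can be said of where it stands. Among the compounds with values here, the only evidence of scale is the limit of > 50000 nM in this assay, at which 1 of the 2 values shown sits.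

Compound 3, with the structure `O=C(Nc1ncc(C(Oc2ccc3cc(Br)ccc3c2)c2ccc(Cl)cc2)s1)c1ccc(Br)cc1`, differs from compound 2 at one place: 4-bromophenyl in place of cyclopropyl on a carbonyl carbon. Within the data shown here, since no step between measured compounds exists, the size of the step in this assay is open; the expectation is for none beyond the usual scatter, with the measurement most likely ending at the limit of the test as well. Compound 3 is therefore estimated to give about 45000 nM in this assay, within a range from 10000 nM to 100000 nM.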

Compound 3, half-maximal cytotoxic concentration: > 50000 nM
Compound 3: only a limit was reported; the forecaster's own chance of this, stated with the estimate: 60%; at least 1.1-fold (0.04 log units) between middle value and limit.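

In this assay compound 3 reaches only a limit of the test (> 50000 nM). Within the data shown here, compound 2 has no number, so no step from compound 2 to compound 3 can be read. The compounds shown leave open at what concentration, if any, either would become toxic to these cells, and the only indication of scale is this: the limit of > 50000 nM in this assay, at which 2 of the 3 values shown sit.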